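The source may hold more compounds than are shown below. What is called first, only, known or untested is meant among the compounds shown, and "the series" means these compounds.

Compound 2, with the structure `Brc1ccc(OCC2=NCCO2)cc1`, belongs to a small pair of close relatives that share one core. Its nearest relative is compound 1, `Clc1ccc(OCC2=NCCO2)cc1`. In a toxicity assay on the whole organism with Rattus norvegicus as the target, at a dose of 100 mg/kg by the oral route (a lower number here means a weaker effect, a higher number a stronger effect of the compound at the dose given), compound 1 gives 10%, and in this assay compound 2 gives 5%. For the measured compounds named here, the one step joining them, a number 5 percentage points lower from compound 1 to compound 2 (within the scatter), came with a bromo in place of a chloro on an aromatic carbon; the two numbers sit within the usual scatter of each other, so neither can be called weaker or stronger.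

Compound 3, `O=[N+]([O-])c1ccc(OCC2=NCCO2)cc1`, is still unmeasured. It differs from compound 2 in one place: nitro in place of bromo on an aromatic carbon. Going by the values given here, no measured step swaps a halogen for a nitro group, so the only guide is the halogen swap between compound 1 and compound 2, which stayed within the scatter. On that basis the change from compound 2 to compound 3 is expected to be a number 5 percentage points higher from compound 2 to compound 3 (within the scatter), with no move beyond the scatter. Compound 3 is therefore estimated at 10%, between 0% and 30%.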

Compound 3, a percentage reported as activity, at one dose (the size of the read-out at that dose, not a potency): 10%
The estimate for compound 3 equals the measured number at the digits printed, within the range that was stated.
By their numbers in this assay, from the lowest: compounds 2, 1 and 3 (each within the scatter of the next).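

For the compounds shown here, at this position, on an aromatic carbon para to a group of 7 heavy atoms, the earlier compounds offered only one halogen in place of another. In this assay the nitro group, with 3 heavy atoms and 2 hydrogen-bond acceptors, now gives a number 5 percentage points higher from compound 2 to compound 3 (within the scatter) and no change at the digits printed from compound 1 to compound 3 (within the scatter) when it takes the place of a single halogen atom. A group of a different kind at this position therefore leaves all three compounds within the scatter of one another, and no measurement shown bears on what lies behind these numbers.

Still open, as far as these compounds go, is whether any group here can move the read-out beyond the scatter, such as an amine, a carboxylic acid or a longer chain. From the compounds shown here alone, all three numbers also come from a single dose, so how these compounds compare at other doses remains unknown.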